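Three Limits and a Fourth Amide Still to Measure

This account rests on a few compounds, and the source may have more. Where it says the series, first, only, none or still open, it means among the compounds named here.

The study concerns a small set of amides built on a shared core. Compound 1 `C=CC1=C(C(=O)Nc2ccccc2OC)C(c2ccc(F)cc2)OC1` carries a 2-methoxyphenyl on its amide nitrogen, while compound 2 `C=CC1=C(C(=O)NCc2ccccc2F)C(c2ccc(F)cc2)OC1` carries a 2-fluorobenzyl there. In a functional assay on A549 cells (Homo sapiens) for cytotoxicity, read by MTT assay, with a stated time of 24 h (a lower number here means a stronger inhibitor, a higher number a weaker inhibitor), compound 1 gives > 100000 nM, which is a limit of the assay and not a number. Compound 2 gives > 100000 nM in this assay, again a limit. Compound 3 `C=CC1=C(C(=O)NCc2ccccc2F)C(c2ccc(OC)cc2)OC1` differs from compound 2 by methoxy in place of fluoro on an aromatic carbon, and in this assay compound 3 gives > 100000 nM, also a limit.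

The step that the two limits leave unreadable from compound 2 to compound 1 rests on the change (2-methoxyphenyl in place of 2-fluorobenzyl on an amide-type nitrogen). The step that the two limits leave unreadable from compound 2 to compound 3 cannot be sized either, because the limit of > 100000 nM in this assay, at which 3 of the 3 values shown sit, holds all three measured values at the same boundary.

Compound 4 `C=CC1=C(C(=O)Nc2ccccc2OC)C(c2ccc(OC)cc2)OC1` has not yet been measured. It differs from compound 3 by 2-methoxyphenyl in place of 2-fluorobenzyl on an amide-type nitrogen, the same kind of change that separates compound 2 from compound 1, made here on the core of compound 3 rather than the core of compound 2; the two cores themselves differ as described by methoxy in place of fluoro on an aromatic carbon.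

Since the step that the two limits leave unreadable from compound 2 to compound 1 is unreadable and compound 3 sits at > 100000 nM, compound 4 is expected to land near the same boundary, with the step that the limit leaves unreadable from compound 3 to compound 4 estimated to be small. The estimate for compound 4 in this assay is 150000 nM, spanning 40000 nM to 600000 nM.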

Compound 4, half-maximal inhibitory concentration: > 100000 nM
Compound 4 gave a limit, no number; the forecaster's own chance of this, stated with the estimate: 85%; the middle value does not contradict the limit.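

In this assay compound 4 gives > 100000 nM, which is a limit and not a number. Among these compounds, no step from compound 3 or compound 1 to compound 4 can be read, because all four compounds stand at one boundary: the limit of > 100000 nM in this assay, at which 4 of the 4 values shown sit. The compounds shown leave open where any of the four would fall if given a number, and whether either change shifts that number at all.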